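The source may hold more compounds than are shown below. What is called first, only, known or untested is meant among the compounds shown, and "the series" means these compounds.

Measured compounds:
Compound 1, `O=C(NCc1ccco1)c1ccccc1OCc1ccccc1`: 49000 nM
Compound 2, `O=C(NC1CCCNC1)c1ccccc1OCc1ccccc1Cl`: only a limit, > 100000 nM
Compound 3, `O=C(Nc1cccnc1)c1ccccc1OCc1cccc(Cl)c1`: 1400 nM

In an assay on lysate for inhibition of phosphatidylcholine:ceramide cholinephosphotransferase 2 (Homo sapiens), read by HPLC, with stated times of 30 min and 2 h (a lower number here means a stronger inhibitor, a higher number a weaker inhibitor), compound 3 has the lowest number of the two that were read as numbers; compound 1, the nearest, sits well beyond the scatter above it. The value of compound 2 is a limit of the assay, not a number.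

Compound 4, `Cc1c(Cl)cccc1COc1ccccc1C(=O)Nc1cccnc1`, differs from compound 3 in one place: methyl in place of hydrogen on an aromatic carbon. Among the measured compounds shown here, no measured pair shows this kind of change, so nothing here tells how large its effect should be. A step of modest size, within the scatter of the assay, is expected from compound 3 to compound 4, a 1.2-fold lower number from compound 3 to compound 4 (0.07 log units; within the scatter). Compound 4 is therefore estimated at 1200 nM, within 300 nM to 5000 nM.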

Compound 4, half-maximal inhibitory concentration: 3800 nM
For compound 4 the middle estimate is 3.2-fold (0.50 log units) below the measured one, and the stated range covers the measured number.
By their numbers in this assay, from the lowest: compound 3; then compound 4; then compound 1. At a limit, above all of these: compound 2.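

In this assay, methyl in place of hydrogen on the aromatic carbon ortho to the chloro group gives a 2.7-fold higher number from compound 3 to compound 4 (0.43 log units; beyond the scatter) and turns 3-chlorophenyl into 3-chloro-2-methylphenyl. Among the compounds shown here, this is the first pair differing in one place, and it shows that this carbon is sensitive to a single added carbon atom. The change is modest, but it moves toward a weaker inhibitor, and compound 3 keeps the lower number.

Going by these compounds, whether a fluorine or a methoxy group on that same carbon would shift the number in the same direction remains open. Nothing measured here accounts for this step.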